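The source may hold more compounds than are shown below. What is called first, only, known or untested is meant among the compounds shown, and "the series" means these compounds.

Compound 1 `COC(=O)c1ccc(-c2nnc(SC3=CS(=O)(=O)c4ccccc43)o2)cc1` gives 4000 nM in an ADME assay on HEK293 cells (Homo sapiens) for cytotoxicity, read by fluorescence and resazurin assay, with a stated time of 24 h; on this read-out higher numbers stand for lower toxicity in this test and lower numbers for higher toxicity in this test.
Compound 2 `Cc1ccc(-c2nnc(SC3=CS(=O)(=O)c4ccccc43)o2)cc1` gives 3000 nM in this assay.
Compound 3 `CC(=O)Nc1ccc(-c2nnc(SC3=CS(=O)(=O)c4ccccc43)o2)cc1` gives 4000 nM in this assay.

Compound 2 sits among its neighbours: the steps of a 1.3-fold lower number from compound 1 to compound 2 (0.12 log units; within the scatter) and a 1.3-fold higher number from compound 2 to compound 3 (0.12 log units; within the scatter) are both within the scatter, so the three numbers cannot be told apart. Compound 4 `O=S1(=O)C=C(Sc2nnc(C3CCCCC3)o2)c2ccccc21` differs from compound 2 by cyclohexyl in place of 4-methylphenyl on an aromatic carbon. The measured steps, a 1.3-fold lower number from compound 1 to compound 2 (0.12 log units; within the scatter), no change at the digits printed from compound 1 to compound 3 (within the scatter) and a 1.3-fold higher number from compound 2 to compound 3 (0.12 log units; within the scatter), all swap groups on the aryl ring and all stay within the scatter; none replaces the aryl ring itself with a cyclohexyl, so they bear only loosely on this change. On that basis no step beyond the scatter is expected, and compound 4 is estimated at 3500 nM, between 1500 nM and 8000 nM, a step of a 1.2-fold higher number from compound 2 to compound 4 (0.07 log units; within the scatter).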

Compound 4, half-maximal cytotoxic concentration: 3000 nM
For compound 4 the middle estimate is 1.2-fold (0.07 log units) above the measured one, and the stated range covers the measured number.
By their numbers in this assay, from the lowest: compounds 2, 4, 1 and 3 (each within the scatter of the next).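

Replacing the whole 4-methylphenyl with cyclohexyl on this carbon of the five-membered ring gives no change at the digits printed from compound 2 to compound 4 (within the scatter) in this assay. The earlier steps shown here only swapped groups on the aromatic ring, whereas this pair shows that a non-aromatic ring of carbon can stand here with no readable difference in this test. Nothing measured here offers an explanation for this. Still open, on these data alone, is whether an open chain such as butyl, or an amine or a carboxylic acid placed directly on this carbon, would give a similar number.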